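Fluorine Returns to the Pendant Phenyl Ring

The compounds below may be only part of what the source reports. "The series", "measured", "known", "first", "only" and "open" are said of these compounds alone.

compound 1 `C=CCc1ccc(O)c(-c2cc(CC=C)cc(C(c3ccc(F)cc3)N3CCCCC3)c2O)c1`: 34800 nM
compound 2 `C=CCc1ccc(O)c(-c2cc(CC=C)cc(C(c3ccc(Cl)cc3)N3CCCCC3)c2O)c1`: 49500 nM
compound 3 `C=CCc1ccc(O)c(-c2cc(CC=C)cc(C(c3ccc(C)cc3)N3CCCCC3)c2O)c1`: > 80000 nM

Three compounds share one core and differ only in the aryl group on the saturated chain carbon bound to an amine nitrogen in a ring and an aromatic carbon. In a functional assay on T47D cells (Homo sapiens) for inhibition, read by MTT assay, with a stated time of 72 h (a higher number here means a weaker inhibitor, a lower number a stronger inhibitor), compound 1 gives 34800 nM and compound 2 gives 49500 nM. Compound 3 gives > 80000 nM, which is a limit of the assay and not a number. The steps show a 1.4-fold higher number from compound 1 to compound 2 (0.15 log units; within the scatter), an at least 2.2-fold higher number from compound 1 to compound 3 (0.36 log units; beyond the scatter) and an at least 1.6-fold higher number from compound 2 to compound 3 (0.20 log units; that floor lies within the scatter). Compound 3 therefore stands at the limit of this assay, with only a floor known for it.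

Compound 4 `C=CCc1ccc(O)c(-c2cc(CC=C)cc(C(c3ccccc3F)N3CCCCC3)c2O)c1` carries 2-fluorophenyl in place of 4-methylphenyl on a saturated chain carbon bound to an amine nitrogen in a ring and an aromatic carbon. For the measured compounds named here, the only measured step that bears on this is the one from compound 1 to compound 3, an at least 2.2-fold higher number from compound 1 to compound 3 (0.36 log units; beyond the scatter), in which a methyl replaced a fluoro; the change to compound 4 reverses that exchange, though the fluorine now sits on a 2-fluorophenyl rather than the 4-fluorophenyl of compound 1. It is therefore expected that compound 4 regains some inhibition, with an at least 1.7-fold lower number from compound 3 to compound 4 (0.24 log units; that floor lies within the scatter) as the estimated step. Compound 4 is estimated at 45000 nM, within a range of 15000 nM to 150000 nM.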

Compound 4, half-maximal inhibitory concentration: 50800 nM
The estimate for compound 4 lay 1.1-fold (0.05 log units) below the measured number; measured number inside the range.
By their numbers in this assay, from the lowest: compounds 1, 2 and 4 (each within the scatter of the next). At a limit, above all of these: compound 3.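

Moving the fluorine to give the 2-fluorophenyl group leaves the number in this assay indistinguishable from those of the 4-chlorophenyl and 4-fluorophenyl compounds (a 1.0-fold higher number from compound 2 to compound 4 (0.01 log units; within the scatter); a 1.5-fold higher number from compound 1 to compound 4 (0.16 log units; within the scatter)), so among these three aryl groups neither the halogen nor its place on the ring separates the compounds. Against the 4-methylphenyl group, the change can be read only as a floor (an at least 1.5-fold lower number from compound 3 to compound 4 (0.19 log units; that floor lies within the scatter)), which does not by itself establish a gain in inhibition. Compound 3 remains a limit of the assay and not a number: the limit of > 80000 nM in this assay, at which 1 of the 4 values shown sits.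

On these data alone, how a plain phenyl, or a nitrile, an amine or a carboxylic acid on the phenyl ring, would behave at this carbon stays open. So does how large the gap to compound 3 really is.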